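Methoxy in place of methyl: cytotoxicity working notes

The compounds below may be only part of what the source reports. "The series", "measured", "known", "first", "only" and "open" are said of these compounds alone.

Of the compounds shown here, two have numbers so far in a functional assay on MT2 cells (Homo sapiens) for cytotoxicity, read by MTT assay; a higher number here means that more compound is tolerated, a lower number that less compound is tolerated. Compound 1 `CC(C)=CCOc1cccc(Nc2nccs2)c1` gives 23000 nM there, and compound 2 `CC(C)=CCOc1cc(Nc2nccs2)ccc1C` gives 17000 nM. Among the compounds with values here, compound 2 therefore stands within the scatter of compound 1, the only other measured compound, and the two are not separated by this assay.

Compound 3 `COc1ccc(Nc2nccs2)cc1OCC=C(C)C` has methoxy in place of methyl on an aromatic carbon, ortho to a (3-methylbut-2-en-1-yl)oxy group and para to a (1,3-thiazol-2-yl)amino group: methoxy in place of methyl on an aromatic carbon.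

Within the data shown here, one measured step bears on this change, methyl in place of hydrogen on that same aromatic carbon, and it is a 1.4-fold lower number from compound 1 to compound 2 (0.13 log units; within the scatter). Among the measured compounds shown here, no methoxy compound has been measured, so the support is thin and the range must stay wide. With that single step as the guide, no shift beyond the scatter is expected in this assay, and no direction is favoured. The estimated step is a 1.2-fold higher number from compound 2 to compound 3 (0.07 log units; within the scatter). For compound 3 the expected value is 20000 nM, with an estimated range from 9000 nM to 45000 nM.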

Compound 3, half-maximal cytotoxic concentration: 42000 nM
Compound 3: middle estimate off by 2.1-fold (0.32 log units), on the low side; low and high end bracket the measured number.
By their numbers in this assay, from the lowest: compounds 2, 1 and 3 (each within the scatter of the next, the first and the last beyond it).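

Within the data shown here, on this aromatic carbon, para to the (1,3-thiazol-2-yl)amino group, this assay now separates two substituents: methoxy in place of methyl gives the only step so far beyond the scatter (a 2.5-fold higher number from compound 2 to compound 3 (0.39 log units; beyond the scatter)), while methyl in place of hydrogen stayed within it (a 1.4-fold lower number from compound 1 to compound 2 (0.13 log units; within the scatter)). Methoxy in place of hydrogen also stays within the scatter (a 1.8-fold higher number from compound 1 to compound 3 (0.26 log units; within the scatter)), so the hydrogen compound, compound 1, is resolved from neither of the other two and only the methyl and methoxy pair is apart, by a modest step. No supporting data bear on why methoxy and methyl differ on this carbon.

As far as these compounds go, whether this separation extends to other groups on the same carbon, such as ethoxy, chlorine or an amine, remains open. Also open, from the compounds shown here alone, is whether it persists when a shorter or longer chain replaces the (3-methylbut-2-en-1-yl)oxy group, or when a different group replaces the (1,3-thiazol-2-yl)amino group, since all three compounds carry both of these unchanged.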